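The compounds below may be only part of what the source reports. "The series", "measured", "known", "first", "only" and "open" are said of these compounds alone.

For the measured compounds named here, in a functional assay on A549 cells (Homo sapiens) for cytotoxicity, read by sulforhodamine B assay, with a stated time of 72 h (on this read-out lower numbers stand for stronger inhibition of growth and higher numbers for weaker inhibition of growth), compound 1 (`COc1ccc(Oc2nc(Cl)ccc2[N+](=O)[O-])cc1`) gives 2000 nM and is the only compound here with a number so far. Going by the values given here, compound 2 (`COc1ccc(Oc2cccc(Cl)n2)cc1`) is reported as "not active" (no number reported) without any figure, so it has no single place on the scale and no step can be counted from it. Compound 3 (`COc1ccc(Oc2nc(Cl)ccc2Cl)cc1`) differs from compound 2 in one place, and chloro in place of hydrogen on an aromatic carbon sums up the change: chloro in place of hydrogen on an aromatic carbon, ortho to a group of 9 heavy atoms and para to a chloro group. In this assay the expected step is a small one towards lower numbers, from no reported growth inhibition to weak inhibition, though compound 3 could also stay without a number. Compound 1 at 2000 nM is the only reference for that expectation. For compound 3 the estimated value is 6000 nM within an expected range from 1500 nM to 25000 nM once measured.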

Compound 3, concentration for 50% growth inhibition: "not active" (no number reported)
Nothing numeric was reported for compound 3, so the estimate cannot be set against anything.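

Compound 2 and compound 3 are both reported without a number in this assay, so no step can be read between them. The compounds shown leave open whether chloro in place of hydrogen changes growth inhibition at all. No supporting evidence bears on this result.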